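The source may hold more compounds than are shown below. What is called first, only, known or untested is meant among the compounds shown, and "the series" means these compounds.

compound 1 `c1ccc(-c2nnc(SCCCN3CCN(c4nc5ccccc5o4)CC3)o2)cc1`: 108000 nM
compound 2 `Fc1ccc(-c2nnc(SCCCN3CCN(c4nc5ccccc5s4)CC3)o2)cc1`: 71700 nM
compound 3 `CC(C)(C)Oc1ccc(-c2nnc(SCCCN3CCN(c4nc5ccccc5s4)CC3)o2)cc1`: 71600 nM

In a functional assay on A549 cells (Homo sapiens) for inhibition, read by MTT assay, with a stated time of 72 h (a lower number here means a stronger inhibitor, a higher number a weaker inhibitor), compound 3 gives 71600 nM. This value lies within the scatter of the other two, so the data set no order among these compounds. Compound 3 therefore stands level with compound 2 and compound 1 on these numbers, and all three sit in the same high range of this assay.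

The next compound, compound 4 `c1ccc(-c2nnc(SCCCN3CCN(c4nc5ccccc5s4)CC3)o2)cc1`, loses the tert-butoxy group of compound 3: hydrogen in place of tert-butoxy on an aromatic carbon. This is hydrogen in place of tert-butoxy on an aromatic carbon, on a six-membered aromatic ring of carbon only, para to a large group.

For the measured compounds named here, one measured step bears directly on this change, because a 1.0-fold lower number from compound 2 to compound 3 (0.00 log units; within the scatter) brings in tert-butoxy in place of fluoro on an aromatic carbon. That step lies within the scatter, so exchanging these two groups left the number without a measurable shift. Going by the values given here, no measurement yet shows hydrogen at this place on the same core, which leaves the estimate resting on that single step. No step beyond the scatter is expected in this assay, in either direction.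

The estimated step is a 1.0-fold higher number from compound 3 to compound 4 (0.02 log units; within the scatter). For compound 4 the expected value is 75000 nM, with an estimated range from 42000 nM to 130000 nM.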

Compound 4, half-maximal inhibitory concentration: 257000 nM
Beside the measured number, compound 4's estimate is 3.4-fold (0.53 log units) below it, and the stated range ends below it.
By their numbers in this assay, from the lowest: compounds 3, 2 and 1 (each within the scatter of the next); then compound 4.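

In this assay, the place on the six-membered aromatic ring, para to a large group, now proves sensitive to its substituent: hydrogen in place of tert-butoxy weakens inhibition (a 3.6-fold higher number from compound 3 to compound 4 (0.56 log units; beyond the scatter)), and hydrogen in place of fluoro does so to a similar extent (a 3.6-fold higher number from compound 2 to compound 4 (0.55 log units; beyond the scatter)), although the exchange of those two groups had shown no measurable shift. Among these compounds, then, the difference lies between hydrogen and either substituent, not between fluoro and tert-butoxy, two groups that differ widely in size. Compound 4 also shows that the group on the ring amine nitrogen matters, as 1,3-benzothiazol-2-yl in place of 1,3-benzoxazol-2-yl goes with a weaker result (a 2.4-fold higher number from compound 1 to compound 4 (0.38 log units; beyond the scatter)), and no evidence is available to explain either effect.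

From the compounds shown here alone, whether a methoxy group, an amine or a carboxylic acid at this place would match fluoro and tert-butoxy remains open. Going by these compounds, it is also open whether a longer chain in the linker would change these numbers, and whether the shift seen with 1,3-benzoxazol-2-yl persists when the phenyl ring carries fluoro or tert-butoxy.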